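This account rests on a few compounds, and the source may have more. Where it says the series, first, only, none or still open, it means among the compounds named here.

Measured so far:
compound 1, `Cc1ccncc1-c1cc(F)cc(-n2nnc(-c3ccccn3)n2)c1`: 5 nM
compound 2, `Cc1ccc(-c2cc(F)cc(-n3nnc(-c4ccccn4)n3)c2)cn1`: 57 nM

In a functional assay for antagonist activity at metabotropic glutamate receptor 5 (Rattus norvegicus) (a lower number here means a stronger inhibitor, a higher number a weaker inhibitor), compound 1 gives 5 nM and compound 2 gives 57 nM. Compound 2 stands highest of the two numbers; its nearest neighbour is compound 1, the gap being an 11-fold higher number from compound 1 to compound 2 (1.06 log units; beyond the scatter). Compound 3, `Cc1cncc(-c2cc(F)cc(-n3nnc(-c4ccccn4)n3)c2)c1`, is not yet measured in this assay; it differs from compound 2 by 5-methylpyridin-3-yl in place of 6-methylpyridin-3-yl on an aromatic carbon. Going by the values given here, only one measured step bears on this, and indirectly: an 11-fold higher number from compound 1 to compound 2 (1.06 log units; beyond the scatter) shows that shifting the methyl on the pyridinyl ring moves the number by a large amount, but no measured compound carries the 5-methyl arrangement, so the direction is open. For compound 3 the estimate in this assay is therefore placed between the two measured values, at 20 nM, with a range of 5 nM to 80 nM. Among the compounds with values here, the expected step is a 2.9-fold lower number from compound 2 to compound 3 (0.45 log units; beyond the scatter), held loosely because an 11-fold higher number from compound 1 to compound 2 (1.06 log units; beyond the scatter) is the only guide.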

Compound 3, half-maximal inhibitory concentration: 499 nM
The estimate for compound 3 lay 25-fold (1.40 log units) below the measured number; the whole stated range lies below it.
By their numbers in this assay, from the lowest: compound 1; then compound 2; then compound 3.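

In this assay, moving the methyl around the methylpyridin-3-yl group now gives three clearly separated values: an 8.8-fold higher number from compound 2 to compound 3 (0.94 log units; beyond the scatter) for 5-methylpyridin-3-yl in place of 6-methylpyridin-3-yl, and a 100-fold higher number from compound 1 to compound 3 (2.00 log units; beyond the scatter) for 5-methylpyridin-3-yl in place of 4-methylpyridin-3-yl. The groups being exchanged have the same atoms and the same counts, so the placement of the methyl alone separates these compounds, with 4-methylpyridin-3-yl giving the lowest number, 6-methylpyridin-3-yl the next and 5-methylpyridin-3-yl the highest, which makes compound 3 the weakest inhibitor of the three. No measurement at hand accounts for this order.

Going by these compounds, the standing of plain pyridin-3-yl, with no methyl, remains open. So does whether an ethyl or methoxy group would follow the same order across these placements.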